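This account rests on a few compounds, and the source may have more. Where it says the series, first, only, none or still open, it means among the compounds named here.

In an ADME assay on microsomes from liver (Rattus norvegicus) for metabolic stability, read by LC-MS, with a stated time of 1 h, at 37 degrees C, tested at 4 uM (a lower number here means that less of the compound is left, a higher number that more of the compound is left), the measured compounds are:

- compound 1 `O=C1c2ccc(OCc3cccc(-c4ccc(Cl)cc4F)c3)cc2CN1C1CCCC1`: "not determined" (no result reported)
- compound 2 `COc1ccc(-c2cccc(COc3ccc4c(c3)CN(C3CCCC3)C4=O)c2)cc1C(=O)O`: 84%
- compound 3 `O=C(O)c1cc(F)cc(-c2cccc(COc3ccc4c(c3)CN(C3CCCC3)C4=O)c2)c1`: 55%

Only two of these compounds have a number. Compound 2 stands at 84%, and compound 3 is the lower of the two at 55%.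

Compound 4 `O=C(O)c1ccc(-c2cccc(COc3ccc4c(c3)CN(C3CCCC3)C4=O)c2)c(Cl)c1` is the next to be measured. It differs from compound 3 in one group: 4-carboxy-2-chlorophenyl in place of 3-carboxy-5-fluorophenyl on an aromatic carbon. The 4-carboxy-2-chlorophenyl group takes the place of the 3-carboxy-5-fluorophenyl group on an aromatic carbon.

Among the measured compounds shown here, only one measured step bears on this change: a number 29 percentage points lower from compound 2 to compound 3 (beyond the scatter). That modest step also exchanged the carboxy-bearing phenyl group, so a change at this place can move the number in this assay. For the measured compounds named here, no measured compound carries the 4-carboxy-2-chlorophenyl group, however, and the data give no firm direction. No step beyond the scatter is therefore expected, and the range is kept wide. The expected step is a number 5 percentage points higher from compound 3 to compound 4 (within the scatter). The estimated value for compound 4 is 60%, with an expected range from 36% to 83%.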

Compound 4, percent of the compound remaining: 3%
Beside the measured number, compound 4's estimate is 57 percentage points above it; the whole stated range lies above it.
By their numbers in this assay, from the lowest: compound 4; then compound 3; then compound 2.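

In this assay, among the compounds shown here, the swap to the 4-carboxy-2-chlorophenyl group gives a number 52 percentage points lower from compound 3 to compound 4 (beyond the scatter) and a number 81 percentage points lower from compound 2 to compound 4 (beyond the scatter), both large, whereas the only earlier step at this place was modest. All three compounds with a number carry a carboxy group on this phenyl ring, so its presence alone does not fix the read-out, and the group's full pattern on the ring can decide between much of the compound remaining and almost none. Nothing measured here gives a reason for this fall.

On these data alone, the chlorine and the place of the carboxy group change together in these steps, so which of them matters stays open. Also open, as far as these compounds go, is how a methyl group in place of the chlorine, or an amide in place of the carboxylic acid, would read in this assay.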